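The compounds below may be only part of what the source reports. "The series", "measured", "known", "first", "only" and "open" are said of these compounds alone.

Compound 1 `CNC(=O)c1cc(Oc2ccc(NS(=O)(=O)c3ccccc3)cc2)ccn1` gives > 40000 nM in a functional assay on PLC-PRF-5 cells (Homo sapiens) for inhibition (on this read-out lower numbers stand for stronger inhibition and higher numbers for weaker inhibition), which is a limit of the assay.
Compound 2 `CNC(=O)c1cc(Oc2ccc(NS(=O)(=O)c3ccc([N+](=O)[O-])cc3)cc2)ccn1` gives > 40000 nM in this assay, which is also a limit of the assay.

Compound 2 therefore stands at the limit, with no number of its own. Within the data shown here, the one measured step, a step that the two limits leave unreadable from compound 1 to compound 2, cannot be sized because both values sit at the limit of > 40000 nM in this assay, at which 2 of the 2 values shown sit. Compound 3 `CNC(=O)c1cc(Oc2ccc(NS(=O)(=O)c3ccc(F)cc3)cc2)ccn1` carries the change (fluoro in place of nitro on an aromatic carbon). Among the measured compounds shown here, no measured step shows what the fluoro does, and the only step that bears on this position is unreadable. Compound 3 is thus expected to remain at the limit, an expected step that the limit leaves unreadable from compound 2 to compound 3 that no shown value can anchor. Compound 3 is estimated at 60000 nM, between 20000 nM and 200000 nM.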

Compound 3, half-maximal inhibitory concentration: > 40000 nM
Compound 3: no number, only a limit (the forecaster's own chance of this, stated with the estimate: 85%); the middle value does not contradict the limit.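

Among these compounds, no step among compound 1, compound 2 and compound 3 can be read, since all three stop at a limit of the assay: the limit of > 40000 nM in this assay, at which 3 of the 3 values shown sit.
In this assay the compounds shown leave open how strongly each one inhibits and whether hydrogen, nitro or fluoro on that aromatic carbon makes any difference.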